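A few compounds are considered here, and "the series" means these few. Any claim that something is new, unique, unknown or untested is made for them only; others in the source may bear on it.

Compound 1 `Nc1c(Br)cc(Br)cc1/C=C(\C(=O)c1ccc(Br)cc1)S(=O)(=O)c1ccc(Br)cc1` gives 25000 nM in a functional assay on DU-145 cells (Homo sapiens) for inhibition, read by trypan blue exclusion, with a stated time of 96 h; a higher number here means a weaker inhibitor of growth, a lower number a stronger inhibitor of growth. Compound 2 `Cc1ccc(CS(=O)(=O)/C(=C/c2c[nH]c3ccc(Br)cc23)C(=O)c2ccc(Cl)cc2)cc1` gives 10000 nM. Compound 3 `O=C(/C(=C\c1ccc(O)c([N+](=O)[O-])c1)SCc1ccc(Br)cc1)c1ccc(C(F)(F)F)cc1` gives 10000 nM.

Among these three, compound 2 stands level with compound 3 at the digits shown, the two together giving the lowest numbers; compound 1 sits furthest from compound 2, its number higher by a margin beyond the scatter. Compound 4 `Cc1ccc(CS(=O)(=O)/C(=C/c2c(O)cc(O)cc2O)C(=O)c2ccc(Cl)cc2)cc1` has not yet been measured in this assay. It differs from compound 2 in one place: 2,4,6-trihydroxyphenyl in place of 5-bromo-1H-indol-3-yl on a double-bonded chain carbon bound to a double-bonded chain carbon. For the measured compounds named here, no measured pair shows this same change, so there is no step to draw on. The step of a 1.5-fold higher number from compound 2 to compound 4 (0.18 log units; within the scatter) is estimated to be small, at most a slight rise in the number. Compound 4 is accordingly expected to give 15000 nM, with a range from 5000 nM to 50000 nM.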

Compound 4, concentration for 50% growth inhibition: > 100000 nM
Compound 4: a limit, no number (the forecaster's own chance of this, stated with the estimate: 25%); middle value at least 6.6-fold (0.82 log units) away from the limit.
By their numbers in this assay, from the lowest: compounds 2 and 3 (each within the scatter of the next); then compound 1. At a limit, above all of these: compound 4.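

In this assay compound 4 gives > 100000 nM, which is a limit of the assay and not a number. On a double-bonded chain carbon bound to a double-bonded chain carbon, 2,4,6-trihydroxyphenyl in place of 5-bromo-1H-indol-3-yl brings an at least 10-fold higher number from compound 2 to compound 4 (1.00 log units; beyond the scatter). For the compounds shown here, this position is therefore not indifferent to the group it carries, which the earlier compounds, joined by no single-place step, could not show.

The compounds shown leave open whether this rise follows from the hydroxyl groups or from the departure of the 5-bromo-1H-indol-3-yl group. An unsubstituted phenyl or a 2,4,6-trimethoxyphenyl group in this place would separate the two.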